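Aryl amide variation on the shared core: toward compound 4

The compounds below may be only part of what the source reports. "The series", "measured", "known", "first", "only" and "open" are said of these compounds alone.

The series keeps one core and varies only the aryl group on the amide carbonyl. Compound 1 `CCOC(=O)N1CCC(N2CCC[C@@H](NC(=O)c3cccc(OC)c3)C2)CC1` gives a limit in a functional assay on CHO cells for agonist activity at muscarinic acetylcholine receptor M5 (Rattus norvegicus) (a higher number here means that more compound is needed for the effect, a lower number that less compound is needed), > 10000 nM. Compound 2 `CCOC(=O)N1CCC(N2CCC[C@@H](NC(=O)c3ccccc3Cl)C2)CC1` likewise gives a limit in this assay, > 10000 nM. Compound 3 `CCOC(=O)N1CCC(N2CCC[C@@H](NC(=O)c3cccs3)C2)CC1` also gives a limit in this assay, > 10000 nM. Hence a step that the two limits leave unreadable from compound 1 to compound 2, a step that the two limits leave unreadable from compound 1 to compound 3 and a step that the two limits leave unreadable from compound 2 to compound 3 cannot be sized, and compound 3 stands where every value so far stands, at the limit of > 10000 nM in this assay, at which 3 of the 3 values shown sit. Compound 4 `CCOC(=O)N1CCC(N2CCC[C@@H](NC(=O)c3ccc(F)cc3C)C2)CC1` carries 4-fluoro-2-methylphenyl in place of thiophen-2-yl on a carbonyl carbon. The measured steps bear on this change only in that none of them showed a readable size, so nothing points to gain or loss in this assay beyond the scatter. Compound 4 is expected near the limit, estimated at 20000 nM with a range of 4000 nM to 100000 nM. The expected step is a step that the limit leaves unreadable from compound 3 to compound 4.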

Compound 4, half-maximal effective concentration: > 10000 nM
Compound 4 ended at the assay's limit (the forecaster's own chance of this, stated with the estimate: 85%); the middle value does not contradict the limit.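

Compound 4 gives a limit in this assay, so its steps from compound 1, compound 2 and compound 3 cannot be read: the limit of > 10000 nM in this assay, at which 4 of the 4 values shown sit.

From the compounds shown here alone, whether any aryl group on the amide carbonyl of the shared core gives a readable value in this assay remains open.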